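The source may report more compounds than this note shows. Statements on the series, on what has been measured and on what is new or still open speak of the compounds shown alone.

Among the compounds with values here, compound 2 `COC(=O)c1cccc(CSc2ccc3c(C)cc(=O)oc3c2)c1` is the only compound here with a measured number: in a functional assay on KBVIN cells (Homo sapiens) for antiproliferative activity, read by sulforhodamine B assay, with a stated time of 72 h (on this read-out lower numbers stand for stronger inhibition of growth and higher numbers for weaker inhibition of growth), compound 2 gives 5410 nM. Compound 1 `Cc1cc(=O)oc2cc(SCc3cccc(C#N)c3)ccc12` gives only a limit of the assay in this assay, > 32500 nM (the limit of > 32500 nM in this assay, at which 1 of the 2 values shown sits). Within the data shown here, the step of an at least 6.0-fold lower number from compound 1 to compound 2 (0.77 log units; beyond the scatter) is the single measured step. Compound 3 `Cc1cc(=O)oc2cc(SCc3cccc(OC(F)(F)F)c3)ccc12` differs from compound 2 by trifluoromethoxy in place of methoxycarbonyl on an aromatic carbon. Among the measured compounds shown here, no measured step exchanges methoxycarbonyl for trifluoromethoxy, so the direction is open; compound 3 is expected to move by a 2.2-fold higher number from compound 2 to compound 3 (0.35 log units; beyond the scatter). Compound 3 is therefore estimated at 12000 nM, within 4000 nM to 40000 nM.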

Compound 3, concentration for 50% growth inhibition: 15300 nM
Estimate against measurement, compound 3: 1.3-fold (0.11 log units) below; measured number inside the range.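

Trifluoromethoxy at this place on the ring gives up part of what methoxycarbonyl gained (a 2.8-fold higher number from compound 2 to compound 3 (0.45 log units; beyond the scatter)), so a group without the carbonyl can still leave measurable growth inhibition. It also does better than the nitrile (an at least 2.1-fold lower number from compound 1 to compound 3 (0.32 log units; beyond the scatter)), which places the three groups in the order methoxycarbonyl, trifluoromethoxy, nitrile, with every step beyond the scatter. As far as these compounds go, compound 1 remains a limit of the assay, so the full size of its gap is unknown: (the limit of > 32500 nM in this assay, at which 1 of the 3 values shown sits).

From the compounds shown here alone, whether an amine, a carboxylic acid or a longer chain here would surpass methoxycarbonyl remains open.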